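This account rests on a few compounds, and the source may have more. Where it says the series, first, only, none or still open, it means among the compounds named here.

In an assay on thoracic aorta for binding affinity to Endothelin-1 receptor (Rattus norvegicus) (a higher number here means a weaker inhibitor, a lower number a stronger inhibitor), compound 3 `Cc1noc(NS(=O)(=O)c2cccc3ccc(N(C)C)cc23)c1C` gives 5600 nM, the highest of the three numbers in hand. Compound 1 `Cc1noc(NS(=O)(=O)c2cccc3ccccc23)c1C` gives 3100 nM, and compound 2 `Cc1noc(NS(=O)(=O)c2cccc3ccc(N)cc23)c1C` gives 1450 nM. Compound 4 `CC(=O)Nc1ccc2cccc(S(=O)(=O)Nc3onc(C)c3C)c2c1` differs from compound 3 by acetamido in place of dimethylamino on an aromatic carbon; the entering group, like the amino of compound 2, carries a hydrogen-bond donor. The measured steps that bear on this change are a 3.9-fold higher number from compound 2 to compound 3 (0.59 log units; beyond the scatter) and a 2.1-fold lower number from compound 1 to compound 2 (0.33 log units; beyond the scatter), both modest and beyond the scatter, while a 1.8-fold higher number from compound 1 to compound 3 (0.26 log units; within the scatter) stays within it. Going by the values given here, a modest downward step, back toward the number of compound 2, is therefore expected, since no compound with the acetamido group has yet been measured. Compound 4 is estimated at 2000 nM with a range of 700 nM to 6000 nM, an expected step of a 2.8-fold lower number from compound 3 to compound 4 (0.45 log units; beyond the scatter) in this assay.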

Compound 4, half-maximal inhibitory concentration: 870 nM
Compound 4: the middle estimate sits 2.3-fold (0.36 log units) above what was measured, within the range that was stated.
By their numbers in this assay, from the lowest: compounds 4 and 2 (each within the scatter of the next); then compounds 1 and 3 (each within the scatter of the next).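

Acetamido at this position gives a 6.4-fold lower number from compound 3 to compound 4 (0.81 log units; beyond the scatter) and so joins amino on the low side of the series, while dimethylamino, with no hydrogen-bond donor, does not. Adding the acetyl group to the nitrogen of compound 2 gives a 1.7-fold lower number from compound 2 to compound 4 (0.22 log units; within the scatter) and leaves the two compounds within the scatter of each other, so the position accepts this larger group. Against the unsubstituted core the result is a 3.6-fold lower number from compound 1 to compound 4 (0.55 log units; beyond the scatter) and lies beyond the scatter.

From the compounds shown here alone, whether a longer acyl chain or a methanesulfonamide on that nitrogen would keep the number near that of compound 4 remains open. No available evidence accounts for these steps.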